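This account rests on a few compounds, and the source may have more. Where it says the series, first, only, none or still open, it means among the compounds named here.

Compound 2 `CC(C)(CCl)C(=O)Nc1cccc(-c2nc3ccccc3s2)c1` sits second highest among the three compounds measured in an ADME assay for permeability, using PAMPA; a higher number here means that the compound crosses the layer faster, a lower number that the compound crosses the layer more slowly. Compound 2 gives 891 10^-6 cm/s, while compound 1 `C/C=C/C(=O)Nc1cccc(-c2nc3ccccc3s2)c1` gives 1640 10^-6 cm/s and compound 3 `O=C(Nc1cccc(-c2nc3ccccc3s2)c1)c1cc([N+](=O)[O-])cnc1Cl` gives 42 10^-6 cm/s. The gap between compound 2 and compound 3 is beyond the scatter, whereas the step of a 1.8-fold lower number from compound 1 to compound 2 (0.26 log units; within the scatter) is within it.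

The next compound, compound 4 `O=C(Nc1cccc(-c2nc3ccccc3s2)c1)c1cnc(Cl)s1`, differs from compound 2 in one place: 2-chloro-1,3-thiazol-5-yl in place of 1-(chloromethyl)-1-methylethyl on a carbonyl carbon. For the measured compounds named here, only one measured step touches that position, a 1.8-fold lower number from compound 1 to compound 2 (0.26 log units; within the scatter), and it exchanged one open chain for another without leaving the scatter. Going by the values given here, no measured step puts an aromatic ring with acceptors in place of a chain at this carbonyl, so there is no direct precedent. Among the compounds with values here, what can be said is that compound 3, the only measured compound whose amide carries an aromatic ring bearing acceptors, shows the lowest value of the three in this assay, and compound 4 moves toward that type of structure.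

Compound 4 is therefore expected to fall below compound 2 in this assay, with the step of a 3.6-fold lower number from compound 2 to compound 4 (0.55 log units; beyond the scatter) estimated beyond the scatter. The estimate for compound 4 is 250 10^-6 cm/s, with a range from 80 10^-6 cm/s to 700 10^-6 cm/s.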

Compound 4, apparent permeability: 133 10^-6 cm/s
The estimate for compound 4 lay 1.9-fold (0.27 log units) above the measured number, and the stated range covers the measured number.
By their numbers in this assay, from the lowest: compound 3; then compound 4; then compounds 2 and 1 (each within the scatter of the next).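

Until now the only step at this carbonyl carbon was one open chain for another, a 1.8-fold lower number from compound 1 to compound 2 (0.26 log units; within the scatter), so the position had not yet been shown to matter in this assay. For the compounds shown here, putting 2-chloro-1,3-thiazol-5-yl in place of 1-(chloromethyl)-1-methylethyl gives a 6.7-fold lower number from compound 2 to compound 4 (0.83 log units; beyond the scatter), the first single change at this position that leaves the scatter. The same ring in place of prop-1-en-1-yl gives a 12-fold lower number from compound 1 to compound 4 (1.09 log units; beyond the scatter), so measured from either chain the exchange of the open group for this aromatic ring lowers the number beyond the scatter, and the position proves sensitive to what is attached there.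

The compounds shown leave open whether this fall belongs to the 2-chloro-1,3-thiazol-5-yl group in particular, or would also follow from an unsubstituted phenyl ring or from a chain ending in an amine on the same carbonyl carbon. Nothing among the data shown gives a reason for the fall.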